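Moving the piperidine swap to the other aryl ether

The compounds below may be only part of what the source reports. "The series", "measured", "known", "first", "only" and "open" are said of these compounds alone.

Three analogues built on the shared core of compound 1 `CCCCc1sc(-c2ccc(Oc3ccc(Cl)cc3)cc2)nc1-c1ccc(OCCCN(CC)CC)cc1` have been measured in an in vitro functional assay on cells (blood brain barrier) for antagonist activity at advanced glycosylation end product-specific receptor (Mus musculus), read by fluorescence, tested at 10 uM; a lower number here means less inhibition, a higher number more inhibition at the concentration tested (going by the name of the read-out). Compound 1 gives 71.7%. Compound 2 `CCCCc1sc(-c2ccc(Oc3ccc(Cl)cc3)cc2)nc1-c1ccc(OCC2CCCN(CC)C2)cc1` gives 68.3%. The step of a number 3.4 percentage points lower from compound 1 to compound 2 (within the scatter) is within the scatter. Compound 3 `CCCCc1sc(-c2ccc(OCCCN(CC)CC)cc2)nc1-c1ccc(Oc2ccc(Cl)cc2)cc1`, which carries the two aryl substituents the other way round, gives 73.3%; this is the largest of the three numbers shown, but the gaps to compound 1 and to compound 2 are both within the scatter, so no order among them can be claimed.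

Compound 4 `CCCCc1sc(-c2ccc(OCC3CCCN(CC)C3)cc2)nc1-c1ccc(Oc2ccc(Cl)cc2)cc1` has not yet been measured. Relative to compound 3 it differs by 1-ethylpiperidin-3-yl in place of 2-(diethylamino)ethyl on a saturated chain carbon bound to an oxygen on an aromatic ring. Among the compounds with values here, the only measured step that bears on it is a number 3.4 percentage points lower from compound 1 to compound 2 (within the scatter), the same exchange made on the other aryl ether, and that step stayed within the scatter. The expectation is therefore a step of a number 3.3 percentage points lower from compound 3 to compound 4 (within the scatter) in this assay, no larger than the scatter. Compound 4 is estimated to give 70%, with a range from 58% to 80%.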

Compound 4, a percentage reported as inhibition, at one concentration (the size of the read-out at that concentration, not a potency): 77.5%
The estimate for compound 4 lay 7.5 percentage points below the measured number; the measured number falls inside the stated range.
By their numbers in this assay, from the lowest: compounds 2, 1, 3 and 4 (each within the scatter of the next).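

In this assay, the exchange of 2-(diethylamino)ethyl for 1-ethylpiperidin-3-yl, made on a saturated chain carbon bound to an oxygen on an aromatic ring, gives a number 4.2 percentage points higher from compound 3 to compound 4 (within the scatter). The change has now been read on both arrangements of the two aryl substituents, and the two steps, opposite in sign, do not differ beyond what such steps can scatter: the same change on two cores in this assay, a number 3.4 percentage points lower (within the scatter) from compound 1 to compound 2 and a number 4.2 percentage points higher (within the scatter) from compound 3 to compound 4, 7.6 percentage points apart, within the scatter of two such steps The shared core therefore accepts (1-ethylpiperidin-3-yl)methyl in place of 3-(diethylamino)propyl on either aryl ether, with no dependence on the arrangement that these numbers can show.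

A read-out at one concentration gives no potency for any of the four compounds. On these data alone, it also remains open whether a carboxylic acid or a morpholine at the end of this side chain would keep the inhibition seen here.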